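The source may hold more compounds than are shown below. What is called first, only, known or untested is meant among the compounds shown, and "the series" means these compounds.

Measured so far:
compound 1, `COc1ccc(Cl)cc1-n1ncc(-c2nnc(-c3cccc(F)c3)o2)c1C`, 4.28
compound 2, `COc1ccc(Cl)cc1-n1ncc(-c2nnc(-c3ccccc3)o2)c1C`, 4.32

In a physicochemical assay for lipophilicity, using the shake flask method, measured as octanol-water partition (a higher number here means a more lipophilic compound, a lower number a more polar compound), compound 2 stands highest of the two values, with compound 1 nearest and within the scatter. Compound 3, `COc1ccc(Cl)cc1-n1ncc(-c2nnc(-c3ccc(C)c(Br)c3)o2)c1C`, differs from compound 2 by 3-bromo-4-methylphenyl in place of phenyl on an aromatic carbon. Within the data shown here, the only measured step, a number 0.04 log units higher from compound 1 to compound 2 (within the scatter), also concerns the ring that is changed here but was within the scatter; no measured step covers a bromine or a methyl on that ring, so the direction rests on the change itself. For compound 3 a rise is expected, a number 1.08 log units higher from compound 2 to compound 3 (beyond the scatter), giving an estimate of 5.4 for compound 3, with a range from 4.9 to 5.9.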

Compound 3, partition coefficient: 5.19
Compound 3: the middle estimate sits 0.21 log units above what was measured; low and high end bracket the measured number.
By their numbers in this assay, from the lowest: compounds 1 and 2 (each within the scatter of the next); then compound 3.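

In this assay this position now shows a step beyond the scatter: 3-bromo-4-methylphenyl in place of phenyl gives a number 0.87 log units higher from compound 2 to compound 3 (beyond the scatter) and in place of 3-fluorophenyl gives a number 0.91 log units higher from compound 1 to compound 3 (beyond the scatter) while the earlier exchange of fluoro for hydrogen stayed within the scatter. The two new steps share one entering group, and their starting compounds, compound 1 and compound 2, lie within the scatter of each other. No measured evidence gives a cause for this rise.

Bromine and methyl enter together, so their separate contributions remain unresolved. As far as these compounds go, how an amine or a carboxylic acid on this phenyl ring would read in this assay also remains open.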